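Methoxy for Methyl on the Aryl Carbamate Ring

This account rests on a few compounds, and the source may have more. Where it says the series, first, only, none or still open, it means among the compounds named here.

Measured in an assay on isolated protein for displacement of a labelled ligand from metabotropic glutamate receptor 5 (Rattus norvegicus); a higher number here means a weaker inhibitor, a lower number a stronger inhibitor:
compound 1, `O=C(Nc1cccc(Cl)c1)O/N=C(\C1CCCCC1)C(Cc1ccccn1)C1CCCCC1`, gives 40.4 nM
compound 2, `O=C(Nc1cccc(F)c1)O/N=C(\C1CCCCC1)C(Cc1cccs1)C1CCCCC1`, gives 12.3 nM
compound 3, `Cc1cccc(NC(=O)O/N=C(\C2CCCCC2)C(Cc2cccs2)C2CCCCC2)c1`, gives 8.3 nM

Compound 3 gives the lowest of the three numbers in this assay. Compound 2 stands nearest to it; its value and that of compound 3 lie within the scatter of each other. Compound 1 stands furthest, and its number is clearly higher, but compound 1 differs from compound 3 in two places, so only the two values themselves can be compared.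

Compound 4, `COc1cccc(NC(=O)O/N=C(\C2CCCCC2)C(Cc2cccs2)C2CCCCC2)c1`, differs from compound 3 by methoxy in place of methyl on an aromatic carbon. For the measured compounds named here, the only measured step at the same place is a 1.5-fold lower number from compound 2 to compound 3 (0.17 log units; within the scatter), a swap of one small substituent for another that stayed within the scatter. Going by the values given here, no measured step covers a methoxy, nor the hydrogen-bond acceptor it brings, so there is nothing to point to a shift in either direction in this assay. Compound 4 is therefore expected to stay close to compound 3, with a 1.2-fold higher number from compound 3 to compound 4 (0.08 log units; within the scatter) as the estimated step. Compound 4 is estimated at 10 nM, in the range 4 nM to 25 nM.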

Compound 4, inhibition constant: 88 nM
The estimate for compound 4 lay 8.8-fold (0.94 log units) below the measured number, and the stated range ends below it.
By their numbers in this assay, from the lowest: compounds 3 and 2 (each within the scatter of the next); then compound 1; then compound 4.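

In this assay, for the compounds shown here, this aromatic carbon proved far less tolerant than the earlier compounds suggested: fluoro and methyl had stayed within the scatter, with a 1.5-fold lower number from compound 2 to compound 3 (0.17 log units; within the scatter), but methoxy gave an 11-fold higher number from compound 3 to compound 4 (1.03 log units; beyond the scatter). The comparison with fluoro points the same way, with a 7.2-fold higher number from compound 2 to compound 4 (0.85 log units; beyond the scatter), so among the three groups at this place, methoxy, which adds one oxygen to methyl, is the one that stands apart. Nothing available on these compounds accounts for this loss.

From the compounds shown here alone, whether a hydroxyl or an ethyl on this carbon would follow methoxy or stay with methyl remains open, which leaves the oxygen and the added heavy atom unseparated. Also open, going by these compounds, is whether methoxy would cost as much on another carbon of this ring, or in the core of compound 1.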